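Two cores, one shortening, and a ceiling not yet broken

This account rests on a few compounds, and the source may have more. Where it says the series, first, only, none or still open, it means among the compounds named here.

Three compounds share a test: a functional assay for inhibition, with Homo sapiens as the target; on this read-out higher numbers stand for weaker inhibition and lower numbers for stronger inhibition. Compound 1, `C=CCn1ncc2c(C)nc(CC)n2c1=O`, is one of them. In this assay compound 1 gives > 48000 nM, which is a limit of the assay rather than a number. Compound 2, `C=CCn1ncc2c(C)nc(C(C)C)n2c1=O`, has the same core as compound 1. In this assay compound 2 gives > 48000 nM, again a limit. Compound 3, `CSc1nncc2c(C)nc(C(C)C)n12`, is built on a different core; the difference between the two cores is not broken down here. In this assay compound 3 gives > 48000 nM, once more a limit. All three values therefore sit at the limit of > 48000 nM in this assay, at which 3 of the 3 values shown sit.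

Compound 1 differs from compound 2 by one change: hydrogen in place of methyl on a saturated chain carbon bound to an aromatic carbon and a saturated chain carbon. Because both ends of this change are limits, the step that the two limits leave unreadable from compound 2 to compound 1 cannot be read as a size.

Compound 4, `CCc1nc(C)c2cnnc(SC)n12`, is not yet measured. It differs from compound 3 by hydrogen in place of methyl on a saturated chain carbon bound to an aromatic carbon and a saturated chain carbon, the same change as that from compound 2 to compound 1, made here on the other core. For the measured compounds named here, since the one earlier instance of this change left both ends at the limit, the expected step that the limit leaves unreadable from compound 3 to compound 4 is estimated to be small. Compound 4 is therefore expected to give about 60000 nM in this assay, most likely reported only as a limit, with an estimated range from 20000 nM to 200000 nM.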

Compound 4, half-maximal inhibitory concentration: > 48000 nM
Compound 4: only a limit was reported (the forecaster's own chance of this, stated with the estimate: 85%); the middle value is on the limit's open side.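

In this assay compound 4 gives > 48000 nM, which is a limit of the assay and not a number. The change from compound 3 to compound 4 therefore cannot be read as a step of any size, since both ends are limits: the limit of > 48000 nM in this assay, at which 4 of the 4 values shown sit.

The compounds shown leave open how strongly any of the four inhibits, and whether going from isopropyl to ethyl matters on either core.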